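Aryl groups on the ring nitrogen of compound 1

This account rests on a few compounds, and the source may have more. Where it says the series, first, only, none or still open, it means among the compounds named here.

Measured compounds:
compound 1 `CC(C)[C@@H]1CC[C@@H](C)C[C@@]12N(C)C(=O)[C@@H]1[C@H]3C(=O)N(C)C(=O)[C@H]3ON12`: 53.4%
compound 2 `CC(C)[C@@H]1CC[C@@H](C)C[C@@]12N(C)C(=O)[C@@H]1[C@H]3C(=O)N(c4ccccc4)C(=O)[C@H]3ON12`: 74.2%
compound 3 `COc1ccc(N2C(=O)[C@H]3[C@H](ON4[C@@H]3C(=O)N(C)[C@@]43C[C@H](C)CC[C@H]3C(C)C)C2=O)cc1`: 61.7%

In a functional assay, with a stated time of 20 min, tested at 2 mg/mL (on this read-out lower numbers stand for a weaker effect and higher numbers for a stronger effect at the one concentration tested), compound 1 gives the lowest of the three numbers; compound 3 lies within the scatter of it, while compound 2 lies beyond it. Compound 4 `Cc1ccc(N2C(=O)[C@H]3[C@H](ON4[C@@H]3C(=O)N(C)[C@@]43C[C@H](C)CC[C@H]3C(C)C)C2=O)c(C)c1` differs from compound 1 in one place: 2,4-dimethylphenyl in place of methyl on an amide-type nitrogen in a ring. Among the compounds with values here, two measured steps bear on this, both also putting an aromatic ring on the same nitrogen: a number 20.8 percentage points higher from compound 1 to compound 2 (beyond the scatter) and a number 8.3 percentage points higher from compound 1 to compound 3 (within the scatter). The first was a modest rise, the second stayed within the scatter. A rise is therefore expected for compound 4, likely of modest size, with the estimate a number 12.6 percentage points higher from compound 1 to compound 4 (beyond the scatter). Compound 4 is expected to give about 66%, in a range from 50% to 82%.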

Compound 4, a percentage reported as activity, at one concentration (the size of the read-out at that concentration, not a potency): 72%
Compound 4: middle estimate off by 6 percentage points, on the low side, and the stated range covers the measured number.
By their numbers in this assay, from the lowest: compounds 1 and 3 (each within the scatter of the next); then compounds 4 and 2 (each within the scatter of the next).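

In this assay, a substituted aromatic ring on this nitrogen can clearly outperform methyl, with a number 18.6 percentage points higher from compound 1 to compound 4 (beyond the scatter), although the 4-methoxyphenyl of compound 3 stayed within the scatter of compound 1. The two substituted rings also separate from each other, with a number 10.3 percentage points higher from compound 3 to compound 4 (beyond the scatter), while 2,4-dimethylphenyl does not separate from plain phenyl, with a number 2.2 percentage points lower from compound 2 to compound 4 (within the scatter). Nothing measured here explains these differences. Still open, going by these compounds, is how an amine or a carboxylic acid on the aromatic ring would fare. On these data alone, a longer alkyl chain on this nitrogen is equally open.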